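Nitrophenyl Swap on a Triazole Amide at the Assay Limit

The source may report more compounds than this note shows. Statements on the series, on what has been measured and on what is new or still open speak of the compounds shown alone.

Compound 1 `CC(C)n1ncc2c(C(=O)NCc3cn(-c4ccccc4)nn3)cccc21`: > 40000 nM
Compound 2 `CC(C)n1ncc2c(C(=O)NCc3cn(-c4cccc(F)c4)nn3)cccc21`: > 40000 nM

Both compounds were tested in a functional assay on HepG2 cells (Homo sapiens) for inhibition, read by MTT assay, with a stated time of 72 h; on this read-out lower numbers stand for stronger inhibition and higher numbers for weaker inhibition. The value of compound 1 is a limit of the assay and not a number. The value of compound 2 is likewise a limit of the assay and not a number. The step that the two limits leave unreadable from compound 1 to compound 2 is therefore unreadable, as the limit of > 40000 nM in this assay, at which 2 of the 2 values shown sit, shows. Compound 2 thus stands at the limit, without a placed number among the values shown.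

Compound 3 `CC(C)n1ncc2c(C(=O)NCc3cn(-c4ccc([N+](=O)[O-])cc4)nn3)cccc21` differs from compound 2 by 4-nitrophenyl in place of 3-fluorophenyl on an aromatic nitrogen. Going by the values given here, the only measured step, from compound 1 to compound 2, touches the same phenyl group but gives no readable size, because both of its ends sit at the limit of > 40000 nM in this assay, at which 2 of the 2 values shown sit. No size or direction beyond the scatter can be expected for this step in this assay, and the expected step that the limit leaves unreadable from compound 2 to compound 3 reflects that. The estimate for compound 3 is 60000 nM, ranging from 20000 nM to 200000 nM, and it is expected most likely to be reported again only as a limit.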

Compound 3, half-maximal inhibitory concentration: > 40000 nM
Compound 3: a limit, no number; the forecaster's own chance of this, stated with the estimate: 85%; the middle value lies beyond the limit too.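

No step among compound 1, compound 2 and compound 3 can be read, because each of their values is a limit of the assay and not a number: the limit of > 40000 nM in this assay, at which 3 of the 3 values shown sit.

The compounds shown leave open what size or direction a change on this phenyl group has in this assay, and whether any group placed there would give a measurable value.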